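From Ethylamino to Pyrrolidin-1-yl on Compound 2

The source may hold more compounds than are shown below. What is called first, only, known or untested is meant among the compounds shown, and "the series" means these compounds.

In a functional assay on MDA-MB-231 cells (Homo sapiens) for antiproliferative activity, read by MTT assay, with a stated time of 72 h (a lower number here means a stronger inhibitor, a higher number a weaker inhibitor), compound 1 `O=C(Nc1ccc(-c2noc(-c3cccc(NS(=O)(=O)c4ccccc4)c3)n2)c(Cl)c1)c1cccnc1` gives > 10000 nM, which is a limit and not a number. Going by the values given here, compound 2 `CCNC(=O)Nc1ccc(S(=O)(=O)Nc2cccc(-c3nc(-c4ccc(NC(=O)c5cccnc5)cc4Cl)no3)c2)cc1` gives 3100 nM, the only actual number so far. Compound 3 `O=C(Nc1ccc(-c2noc(-c3cccc(NS(=O)(=O)c4ccc(NC(=O)N5CCCC5)cc4)c3)n2)c(Cl)c1)c1cccnc1` has pyrrolidin-1-yl in place of ethylamino on a carbonyl carbon. Among the compounds with values here, only one measured step bears on this, an at least 3.2-fold lower number from compound 1 to compound 2 (0.50 log units; beyond the scatter), and it shows (ethylcarbamoyl)amino replacing hydrogen, not that group being altered, so no change beyond the scatter is expected in this assay. The expected step is a 1.0-fold lower number from compound 2 to compound 3 (0.01 log units; within the scatter). For compound 3 the estimated value is 3000 nM, within a range of 1000 nM to 10000 nM.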

Compound 3, half-maximal inhibitory concentration: 5800 nM
Compound 3: middle estimate off by 1.9-fold (0.29 log units), on the low side, within the range that was stated.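

In this assay, pyrrolidin-1-yl in place of ethylamino on this carbonyl carbon gives a 1.9-fold higher number from compound 2 to compound 3 (0.27 log units; within the scatter), so this position accepts a five-membered ring without a hydrogen-bond donor, and the two compounds cannot be told apart. Measured from compound 1, the added group gives an at least 1.7-fold lower number from compound 1 to compound 3 (0.23 log units; that floor lies within the scatter), which is only a floor because compound 1 stands at a limit of the assay: the limit of > 10000 nM in this assay, at which 1 of the 3 values shown sits.

As far as these compounds go, whether a morpholine, a dimethylamino group or a longer chain on this carbonyl carbon would shift the number beyond the scatter remains open.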